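The compounds below may be only part of what the source reports. "The series", "measured", "known", "first", "only" and "open" are said of these compounds alone.

Going by the values given here, the two compounds measured so far share one core. Compound 1 `Fc1cccc(-c2nc(Nc3ccccc3Cl)c3cc(F)ccc3n2)c1` carries a 2-chlorophenyl on a nitrogen on an aromatic ring, and in a functional assay on HL-60 cells (Homo sapiens) for cytotoxicity, read by MTT assay, with a stated time of 48 h (a lower number here means a stronger inhibitor, a higher number a weaker inhibitor), compound 1 gives only a limit of > 50000 nM. Compound 2 `Oc1ccc(Nc2nc(-c3cccc(F)c3)nc3ccc(F)cc23)cc1` carries a 4-hydroxyphenyl in that place, and in this assay compound 2 likewise gives only a limit of > 50000 nM. The step that the two limits leave unreadable from compound 1 to compound 2 cannot be read, since both ends sit at the limit of > 50000 nM in this assay, at which 2 of the 2 values shown sit. Compound 2 thus stands at the edge of what this assay can report, with no number of its own.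

Compound 3 `Oc1cccc(Nc2nc(-c3cccc(F)c3)nc3ccc(F)cc23)c1` differs from compound 2 by 3-hydroxyphenyl in place of 4-hydroxyphenyl on a nitrogen on an aromatic ring. No measured step speaks to this change; the one step shown, from compound 1 to compound 2, is unreadable, and nothing sets a size or direction to expect. With both known compounds at the limit, the expectation for compound 3 is that this assay will again report a limit, and a readable number would be unexpected. Compound 3 is expected to give about 50000 nM in this assay, within 8000 nM to 200000 nM. The expected step is a number no higher from compound 2 to compound 3 (the limit leaves the size open), meaning no change that can be told apart.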

Compound 3, half-maximal inhibitory concentration: > 50000 nM
Compound 3: a limit, no number (the forecaster's own chance of this, stated with the estimate: 75%); the middle value lies on the limit itself.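

Compound 3, like compound 1 and compound 2, gives only a limit in this assay and not a number, so none of the steps among these three compounds can be read. Left open is how the three actually compare in this assay and whether any other group on that nitrogen would give a readable number.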